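Compound 1 to compound 4: bromo in place of methyl

The source may hold more compounds than are shown below. What is called first, only, known or untested is meant among the compounds shown, and "the series" means these compounds.

Measured in an ADME assay on MDBK cells (Bos taurus) for cytotoxicity, read by MTT assay, with a stated time of 72 h; on this read-out lower numbers stand for higher toxicity in this test and higher numbers for lower toxicity in this test:
compound 1 `Cc1ccc(NCc2cn(-c3ccccc3)nc2-c2ccc(C(F)(F)F)cc2)cc1`: > 100000 nM
compound 2 `Cc1ccc(NCc2cn(-c3ccccc3)nc2-c2ccccc2)cc1`: > 100000 nM
compound 3 `Cc1ccc(NCc2cn(-c3ccccc3)nc2-c2ccc(Br)cc2)cc1`: > 100000 nM

Compound 1 gives no number, only > 100000 nM, which is a limit of the assay. The series offers nothing else: the limit of > 100000 nM in this assay, at which 3 of the 3 values shown sit. Compound 4 `FC(F)(F)c1ccc(-c2nn(-c3ccccc3)cc2CNc2ccc(Br)cc2)cc1` differs from compound 1 by bromo in place of methyl on an aromatic carbon, that is 4-methylphenyl to 4-bromophenyl, para to a large group. The measured steps are a step that the two limits leave unreadable from compound 1 to compound 2, a step that the two limits leave unreadable from compound 1 to compound 3 and a step that the two limits leave unreadable from compound 2 to compound 3. None has a readable size, and none touches this methyl. No step beyond the scatter is expected in this assay, and another limit is the likeliest report. The estimated change is a number no higher from compound 1 to compound 4 (the limit leaves the size open). For compound 4 the estimated value is 100000 nM, with an expected range of 50000 nM to 200000 nM.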

Compound 4, half-maximal cytotoxic concentration: 64000 nM
Compound 4: the middle estimate sits 1.6-fold (0.19 log units) above what was measured; measured number inside the range.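

In this assay, for the compounds shown here, the change from 4-methylphenyl to 4-bromophenyl gives an at least 1.5-fold lower number from compound 1 to compound 4 (0.19 log units; that floor lies within the scatter) and is the first step with a readable size. Its floor does not separate the change from the scatter, so no real shift at this position is established. Compound 4 is the only compound shown that carries a number rather than a limit: the limit of > 100000 nM in this assay, at which 3 of the 4 values shown sit.

From the compounds shown here alone, the true size of the step stays open, since compound 1 has only a limit. Also open, going by these compounds, is whether an amine or a carboxylic acid in place of the methyl would give a number further down.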